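A few compounds are considered here, and "the series" means these few. Any claim that something is new, unique, unknown or untested is made for them only; others in the source may bear on it.

In a functional assay on V79 cells (Cricetulus griseus) for cytotoxicity, read by colony formation (on this read-out lower numbers stand for stronger inhibition and higher numbers for weaker inhibition), compound 3 (`CNCC1(C)CCN(c2c(F)cc3c(=O)c(C(=O)O)cn(C4CC4)c3c2Cl)C1`) gives 23 ug/mL. Compound 1 (`NCC1CCN(c2c(F)cc3c(=O)c(C(=O)O)cn(C4CC4)c3c2C(F)(F)F)C1`) gives 38 ug/mL, and the numbers of compound 1 and compound 3 lie within the scatter of each other. Compound 2 (`CCNCC1CCN(c2c(F)cc3c(=O)c(C(=O)O)cn(C4CC4)c3c2C(F)(F)F)C1`) gives 120 ug/mL. The gap between compound 2 and compound 3 lies beyond the scatter, with compound 3 on the low side. Compound 4 (`CNCC1(C)CCN(c2c(F)cc3c(=O)c(C(=O)O)cn(C4CC4)c3c2C(F)(F)F)C1`) differs from compound 3 in one place: trifluoromethyl in place of chloro on an aromatic carbon. Within the data shown here, no measured step covers this exchange. Among the measured compounds shown here, compounds 1 and 2 both carry trifluoromethyl, but the one step between them, a 3.2-fold higher number from compound 1 to compound 2 (0.50 log units; beyond the scatter), concerns an amine nitrogen and bears on it only indirectly. In this assay a small move toward a higher number is therefore expected, a 1.7-fold higher number from compound 3 to compound 4 (0.24 log units; within the scatter). The estimate for compound 4 is 40 ug/mL, with an expected range of 15 ug/mL to 110 ug/mL.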

Compound 4, half-maximal inhibitory concentration: 230 ug/mL
Beside the measured number, compound 4's estimate is 5.8-fold (0.76 log units) below it; the whole stated range lies below it.
By their numbers in this assay, from the lowest: compounds 3 and 1 (each within the scatter of the next); then compounds 2 and 4 (each within the scatter of the next).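

In this assay, among these compounds, the exchange of chloro for trifluoromethyl on this aromatic carbon, ortho to the 3-methyl-3-((methylamino)methyl)pyrrolidin-1-yl group, gives the only direct reading at this position (a 10-fold higher number from compound 3 to compound 4 (1.00 log units; beyond the scatter)), and it shows that the position responds clearly to this change. With trifluoromethyl kept, changing the pyrrolidinyl group gives a step beyond the scatter in one case (a 6.1-fold higher number from compound 1 to compound 4 (0.78 log units; beyond the scatter)) and within it in the other (a 1.9-fold higher number from compound 2 to compound 4 (0.28 log units; within the scatter)). Nothing available gives a reason for these numbers. From the compounds shown here alone, whether a methoxy group or bromo on this carbon would stay near chloro or near trifluoromethyl remains open. So does whether chloro has the same effect with the 3-(aminomethyl)pyrrolidin-1-yl group.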